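This account rests on a few compounds, and the source may have more. Where it says the series, first, only, none or still open, it means among the compounds named here.

Compound 1 `CC(C)C(c1ncco1)c1ccc(-c2ccc3cccc(F)c3c2)[nH]c1=O` gives 0.178 h in an ADME assay on microsomes from liver (Homo sapiens) for metabolic stability; a higher number here means that the compound lasts longer, a lower number that the compound disappears faster.
Compound 2 `CC(C)[C@H](C[C@H]1CCNC1=O)c1ccc(-c2ccc3cccc(F)c3c2)[nH]c1=O` gives 0.257 h in this assay.

These two numbers lie within the usual scatter of each other, so compound 1 cannot be set apart from compound 2 on this evidence. Compound 3 `CC(C)C(c1noc(=O)[nH]1)c1ccc(-c2ccc3cccc(F)c3c2)[nH]c1=O` is not yet measured in this assay. It differs from compound 1 in one place: a group of 6 heavy atoms (2 carbon, 2 nitrogen, 2 oxygen; one five-membered aromatic ring with 3 hetero atoms) in place of a group of 5 heavy atoms (3 carbon, 1 nitrogen, 1 oxygen; one five-membered aromatic ring with 2 hetero atoms), on a saturated chain carbon bound to an aromatic carbon and a saturated chain carbon. Among the measured compounds shown here, no measured pair shows such a change, so the expected step from compound 1 to compound 3 is set as a small one, a 1.2-fold higher number from compound 1 to compound 3 (0.09 log units; within the scatter), not clearly beyond the scatter. For compound 3 the estimate in this assay is 0.22 h, with a range from 0.12 h to 0.4 h.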

Compound 3, half-life: > 3 h
Compound 3 was reported as a limit; the forecaster's own chance of this, stated with the estimate: 5%; middle value at least 13-fold (1.13 log units) from the limit.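

Among the compounds shown here, no earlier pair showed a step at this position, the saturated chain carbon bound to an aromatic carbon and a saturated chain carbon. In this assay, replacing 1,3-oxazol-2-yl with the five-membered aromatic ring with 3 hetero atoms gives an at least 16-fold higher number from compound 1 to compound 3 (1.22 log units; beyond the scatter), so one ring exchange here can change the half-life far beyond the scatter. The true size of this step remains unknown because the value for compound 3 is a limit of the assay, not a number: the limit of > 3 h in this assay, at which 1 of the 3 values shown sits.

Which difference between the two rings matters remains open, including the added hydrogen-bond donor. Also open, going by these compounds, is whether a carboxylic acid in the same place would give a step of similar size.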